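The source may hold more compounds than are shown below. What is called first, only, known or untested is meant among the compounds shown, and "the series" means these compounds.

Values in a toxicity assay on HepG2 2.2.15 cells (Homo sapiens) for cytotoxicity, read by CellTiter-Glo; a higher number here means that more compound is tolerated, a lower number that less compound is tolerated:
- compound 1 `O=C1CC(c2ncc(F)cn2)CN1c1cnn2c1CN(C(=O)Nc1cc(F)c(F)c(F)c1)C(C1CC1)C2`: 115000 nM
- compound 2 `O=C1CC(c2ccc(F)cc2)CN1c1cnn2c1CN(C(=O)Nc1cc(F)c(F)c(F)c1)C(C1CC1)C2`: 32100 nM

Of these two, compound 2 has the lower number, 32100 nM, so less of compound 1 is needed to harm... 

Correction, final text:

Values in this assay: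
- compound 1 `O=C1CC(c2ncc(F)cn2)CN1c1cnn2c1CN(C(=O)Nc1cc(F)c(F)c(F)c1)C(C1CC1)C2`: 115000 nM
- compound 2 `O=C1CC(c2ccc(F)cc2)CN1c1cnn2c1CN(C(=O)Nc1cc(F)c(F)c(F)c1)C(C1CC1)C2`: 32100 nM

Of the two compounds, compound 2 stands lowest at 32100 nM, which means that the cells tolerate less of it. Compound 3 `O=C1CC(c2ccc(F)cn2)CN1c1cnn2c1CN(C(=O)Nc1cc(F)c(F)c(F)c1)C(C1CC1)C2` has not yet been measured. It differs from compound 2 in one place: 5-fluoropyridin-2-yl in place of 4-fluorophenyl on a saturated ring carbon. Put simply, 5-fluoropyridin-2-yl takes the place of 4-fluorophenyl on a saturated ring carbon.

Going by the values given here, only one measured step bears on this change. It is a 3.6-fold lower number from compound 1 to compound 2 (0.55 log units; beyond the scatter), a modest move beyond the usual scatter, made when 4-fluorophenyl replaced 5-fluoropyrimidin-2-yl on the same carbon. Like the group in compound 1, the incoming group has hetero atoms in its aromatic ring, so part of that step may be undone. A single step is a thin guide, however, and the expected rise in this assay is therefore smaller than that step, and it could stay within the scatter. The expected change is a 1.9-fold higher number from compound 2 to compound 3 (0.27 log units; within the scatter). Compound 3 is estimated at 60000 nM, with an expected range of 28000 nM to 125000 nM.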

Compound 3, half-maximal cytotoxic concentration: 38500 nM
The estimate for compound 3 lay 1.6-fold (0.19 log units) above the measured number, and the stated range covers the measured number.
By their numbers in this assay, from the lowest: compounds 2 and 3 (each within the scatter of the next); then compound 1.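

In this assay, putting 5-fluoropyridin-2-yl in place of 4-fluorophenyl on this saturated ring carbon gives a 1.2-fold higher number from compound 2 to compound 3 (0.08 log units; within the scatter) and so does not separate the two compounds, which shows that the one hetero atom in the entering ring is not enough on its own to shift the reading. Going by these compounds alone, putting 5-fluoropyridin-2-yl in place of 5-fluoropyrimidin-2-yl at the same carbon gives a 3.0-fold lower number from compound 1 to compound 3 (0.48 log units; beyond the scatter) and so sets compound 1 apart from both compound 2 and compound 3, making 5-fluoropyrimidin-2-yl the only one of these three groups tied to a clear difference. No measurement at hand explains why the compounds read as they do.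

Within the data shown here, with only three aromatic rings compared at this carbon, it remains open whether the higher tolerance seen for compound 1 is particular to 5-fluoropyrimidin-2-yl or would extend to other rings with hetero atoms. On these data alone, it is also open how a group of a different kind, such as an amine or a carboxylic acid, would read at this carbon in this assay on the shared core.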